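Adding one fluoro to the strongest of three compounds

This account rests on a few compounds, and the source may have more. Where it says the series, first, only, none or still open, it means among the compounds named here.

- compound 1 `COc1cc2c(Oc3ccc(NC(=O)Nc4ccccc4Cl)cc3)ccnc2cc1OCCCCCCC(=O)NO` gives 2780 nM
- compound 2 `COc1cc2c(Oc3ccc(NC(=O)Nc4ccc(C)cc4C)cc3)ccnc2cc1OCCCCCCC(=O)NO` gives 3430 nM
- compound 3 `COc1cc2c(Oc3ccc(NC(=O)N/N=C/c4ccccc4)cc3)ccnc2cc1OCCCCCCC(=O)NO` gives 610 nM

All three values come from a functional assay on MCF7 cells (Homo sapiens) for antiproliferative activity, read by MTT assay (on this read-out lower numbers stand for stronger inhibition and higher numbers for weaker inhibition), and compound 3 has the lowest number among them. The gaps are clear, since a 4.6-fold lower number from compound 1 to compound 3 (0.66 log units; beyond the scatter) and a 5.6-fold lower number from compound 2 to compound 3 (0.75 log units; beyond the scatter) both lie beyond the scatter.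

Compound 4 `COc1cc2c(Oc3ccc(NC(=O)N/N=C/c4ccc(F)cc4)cc3)ccnc2cc1OCCCCCCC(=O)NO` differs from compound 3 in one place only, with fluoro in place of hydrogen on an aromatic carbon as the whole change, para to a large group. For the measured compounds named here, no measured step makes this exact swap. The two steps above replace the entire group on an amide-type nitrogen, so they say little about a single new atom. The closest in kind is a 1.2-fold higher number from compound 1 to compound 2 (0.09 log units; within the scatter) on the ring, and it stays within the scatter. In this assay no step beyond the scatter is therefore expected, and no clear direction either. An estimated 1.1-fold lower number from compound 3 to compound 4 (0.02 log units; within the scatter) is what this reasoning gives. Compound 4 is estimated at 580 nM with an expected range of 250 nM to 1300 nM for the measurement.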

Compound 4, half-maximal inhibitory concentration: 1360 nM
Beside the measured number, compound 4's estimate is 2.3-fold (0.37 log units) below it; measured number outside the range, above it.
By their numbers in this assay, from the lowest: compound 3; then compound 4; then compounds 1 and 2 (each within the scatter of the next).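

In this assay, going from phenyl to 4-fluorophenyl gives a 2.2-fold higher number from compound 3 to compound 4 (0.35 log units; beyond the scatter), so this place on the ring does respond to a single added atom, and here the added fluoro weakens inhibition. For the compounds shown here, the change does not remove the lead of this side group over those of the earlier compounds, since a 2.5-fold lower number from compound 2 to compound 4 (0.40 log units; beyond the scatter) and a 2.0-fold lower number from compound 1 to compound 4 (0.31 log units; beyond the scatter) both remain beyond the scatter. Nothing shown here gives a reason for the rise caused by this one atom.

The compounds shown leave open whether the loss belongs to fluoro itself or would come with any group at this place, which a chloro, a methoxy or an amine there would begin to tell. They also leave open whether other places on this ring respond in the same way.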